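Moving the halogen on the sulfonyl ring of compound 1

The source may report more compounds than this note shows. Statements on the series, on what has been measured and on what is new or still open speak of the compounds shown alone.

Compound 1 `O=C(NCc1ccc(CNS(=O)(=O)c2cccc(Cl)c2)cc1)c1ccc(CNc2ncccn2)cc1` is the starting point of this step. In an assay on MDA-MB-231 cells for binding affinity to C-X-C chemokine receptor type 4 (Homo sapiens), read by microscopy, with stated times of 10 min and 30 min (on this read-out higher numbers stand for an effect only at larger amounts of compound and lower numbers for an effect already at smaller amounts), compound 1 gives 1 nM, the lowest of the three numbers shown. Compound 3 `O=C(NCc1ccc(CNS(=O)(=O)c2cccc(F)c2)cc1)c1ccc(CNc2ncccn2)cc1`, which carries fluoro in place of chloro on an aromatic carbon, gives 1000 nM in this assay, and compound 2 `O=C(NCc1ccc(CNS(=O)(=O)c2ccc(-c3ccc(F)cc3)cc2)cc1)c1ccc(CNc2ncccn2)cc1`, whose sulfonyl ring carries a fluorophenyl group, gives 1000 nM. Among the compounds with values here, the one measured step that bears directly on the change at hand is a 1000-fold higher number from compound 1 to compound 3 (3.00 log units; beyond the scatter).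

Compound 4 `O=C(NCc1ccc(CNS(=O)(=O)c2ccc(F)cc2)cc1)c1ccc(CNc2ncccn2)cc1` differs from compound 1 by a single replacement: 4-fluorophenyl in place of 3-chlorophenyl on a sulfonyl sulfur. This swaps the halogen and at the same time moves it to another position on the same ring. Within the data shown here, no measured pair separates these two parts of the change, so the expectation rests on the halogen swap alone. A large step toward a higher number is expected for compound 4 because a 1000-fold higher number from compound 1 to compound 3 (3.00 log units; beyond the scatter), and the reading of compound 2 at 1000 nM points the same way. The step expected for compound 4 is therefore a 1000-fold higher number from compound 1 to compound 4 (3.00 log units; beyond the scatter). In this assay compound 4 is expected to give 1000 nM, with a likely range from 100 nM to 5000 nM.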

Compound 4, effective concentration (reported as EC, without a stated level of effect): > 1000 nM
Compound 4: only a limit was reported; the forecaster's own chance of this, stated with the estimate: 10%; the middle value sits exactly at the limit.
By their numbers in this assay, from the lowest: compound 1; then compounds 2 and 3 (each within the scatter of the next).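

In this assay the reading for compound 4 is a limit and not a number: the limit of > 1000 nM in this assay, at which 1 of the 4 values shown sits.

Even so, the change of 4-fluorophenyl in place of 3-chlorophenyl on a sulfonyl sulfur can be read as an at least 1000-fold higher number from compound 1 to compound 4 (3.00 log units; beyond the scatter), and this extends what the earlier compounds showed, since compound 1 with its 3-chlorophenyl group now stands apart from all three compounds shown that carry fluorine on this part of the molecule, with none going against this among the four. The other two steps cannot be read, as the limit leaves their size open: the data give only a number no lower from compound 3 to compound 4 (the limit leaves the size open) and a number no lower from compound 2 to compound 4 (the limit leaves the size open) and so moving the fluoro from the 3-fluorophenyl group of compound 3 to the 4-fluorophenyl group of compound 4 has no measured size.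

As far as these compounds go, it remains open whether the low number of compound 1 belongs to the chlorine itself or to where it sits on the ring, and a 4-chlorophenyl group on the sulfonyl sulfur would separate these two parts of the change. Also open, from the compounds shown here alone, is what number a 3-bromophenyl or a 3-methylphenyl group in the same place would give.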